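Swapping phenyl for chloro on the aromatic ring of compound 2

The source may report more compounds than this note shows. Statements on the series, on what has been measured and on what is new or still open speak of the compounds shown alone.

Of the compounds shown here, two have been measured in a functional assay on CHO cells for agonist activity at prostaglandin E2 receptor EP4 subtype (Rattus norvegicus), read by cAMP accumulation and immunoassay, with a stated time of 10 min; on this read-out lower numbers stand for an effect already at smaller amounts and higher numbers for an effect only at larger amounts of compound. Compound 1 `O=C(O)CCCSCCN1C(=O)OC[C@@H]1/C=C/[C@@H](O)Cc1cccc(C(F)(F)F)c1` gives 12 nM, and compound 2 `O=C(O)CCCSCCN1C(=O)OC[C@@H]1/C=C/[C@@H](O)Cc1cccc(-c2ccccc2)c1` gives 450 nM. Compound 2 therefore carries the higher of the two numbers: the change from compound 1 to compound 2, phenyl in place of trifluoromethyl on an aromatic carbon, brought a 38-fold higher number from compound 1 to compound 2 (1.57 log units; beyond the scatter).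

Compound 3 `O=C(O)CCCSCCN1C(=O)OC[C@@H]1/C=C/[C@@H](O)Cc1cccc(Cl)c1` has not yet been measured in this assay. It differs from compound 2 in one place: chloro in place of phenyl on an aromatic carbon. Within the data shown here, only one measured step bears on this change, the one from compound 1 to compound 2, where replacing trifluoromethyl by phenyl moved the number by a 38-fold higher number from compound 1 to compound 2 (1.57 log units; beyond the scatter). Among the measured compounds shown here, compound 3 undoes the phenyl but puts chloro, not trifluoromethyl, in its place, so the single step gives only an indirect guide. The expectation for compound 3 is a step of an 18-fold lower number from compound 2 to compound 3 (1.26 log units; beyond the scatter), that is a clearly lower number than compound 2. The estimate for compound 3 in this assay is 25 nM, with a range from 6 nM to 100 nM.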

Compound 3, half-maximal effective concentration: 23 nM
For compound 3 the middle estimate is 1.1-fold (0.04 log units) above the measured one; the measured number falls inside the stated range.
By their numbers in this assay, from the lowest: compounds 1 and 3 (each within the scatter of the next); then compound 2.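

In this assay, the step of a 20-fold lower number from compound 2 to compound 3 (1.29 log units; beyond the scatter) shows that trifluoromethyl is not needed to leave the high number of compound 2 behind, since a single chlorine atom on the same aromatic carbon does so in place of the six carbons of phenyl. The step of a 1.9-fold higher number from compound 1 to compound 3 (0.28 log units; within the scatter) lies within the scatter, so chloro and trifluoromethyl cannot be told apart at this place, and phenyl is the group that stands apart among the three; the earlier step alone could not separate losing trifluoromethyl from gaining phenyl. No accompanying measurement offers an explanation for the gap between phenyl and the other two groups.

The compounds shown leave open whether the high number goes with phenyl alone or also with other ring-bearing groups, such as cyclopropyl or pyridyl, at this place. They also leave open where a methyl, a methoxy or an amine on this carbon would fall, and whether a bare hydrogen there would give a number closer to that of compound 2 or to that of compound 3.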